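The source may hold more compounds than are shown below. What is called first, only, known or untested is meant among the compounds shown, and "the series" means these compounds.

Working notes on the series.

Compound 1 `Nc1cc(N)c2nc(-c3ccccc3)c(Oc3ccc(Cl)c(Cl)c3)nc2c1` is the starting point. For the measured compounds named here, in a functional assay on SW-620 cells (Homo sapiens) for inhibition, read by sulforhodamine B assay, with a stated time of 48 h (a lower number here means a stronger inhibitor of growth, a higher number a weaker inhibitor of growth), compound 1 gives 9770 nM, which is the only actual number among the values recorded so far. Compound 2 `CCOC(=O)[C@H](CCC(=O)O)NC(=O)c1ccc(CNc2nc3cc(N)cc(N)c3nc2-c2ccccc2)cc1` carries a different substituent on the same core. In this assay compound 2 is recorded only as a limit of < 100000 nM, not as a number; this is the situation summarised by the limit of < 100000 nM in this assay, at which 1 of the 2 values shown sits. Going by the values given here, no step between two measured compounds can therefore be stated, and compound 1 stands alone as the single numerical reference.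

Compound 3 `Nc1cc(N)c2nc(-c3ccccc3)c(Sc3ccc(Cl)c(Cl)c3)nc2c1` is not yet measured. It differs from compound 1 by (3,4-dichlorophenyl)sulfanyl in place of 3,4-dichlorophenoxy on an aromatic carbon. The aryl ring with its two chlorines is retained; only the linking atom changes. Among the compounds with values here, with no measured step available to calibrate this exchange, the expectation is a step of a 1.2-fold lower number from compound 1 to compound 3 (0.09 log units; within the scatter), not beyond the usual scatter in either direction. For compound 3 the estimate is 8000 nM, with a range from 3000 nM to 25000 nM.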

Compound 3, concentration for 50% growth inhibition: 20900 nM
Compound 3: the middle estimate sits 2.6-fold (0.42 log units) below what was measured; low and high end bracket the measured number.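

In this assay, for the compounds shown here, the exchange of 3,4-dichlorophenoxy for (3,4-dichlorophenyl)sulfanyl on an aromatic carbon next to the ring nitrogen gives a 2.1-fold higher number from compound 1 to compound 3 (0.33 log units; beyond the scatter) and so supplies the first step that can be read as a number. This position therefore responds to a change of the linking atom alone, with the aryl ring and its two chlorines retained and the heavy-atom count of the group unchanged, and compound 3 is the weaker inhibitor of growth of this pair by a modest margin. Nothing on hand accounts for the direction or size of this step.

It remains open whether this step reflects a wider trend at the position, as a single exchange is shown and a methylene or sulfonyl link carrying the same 3,4-dichlorophenyl ring would be needed to test it. Steps involving compound 2 cannot be read, as its entry of < 100000 nM is a limit and not a number.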